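Trading Methoxy for Methyl: A Modest Loss Expected

The source may report more compounds than this note shows. Statements on the series, on what has been measured and on what is new or still open speak of the compounds shown alone.

Compound 2 `COc1ccc(C(=O)c2sc(Nc3ccccc3)c(C(=O)O)c2C)cc1` holds the higher of the two numbers recorded: in a functional assay, with a stated time of 150 min, tested at 10 ug/mL (on this read-out higher numbers stand for a stronger effect at the one concentration tested and lower numbers for a weaker effect), compound 2 gives 24.7%, whereas compound 1 `COC(=O)c1c(Nc2ccccc2)sc(C(=O)c2ccc(C)cc2)c1C` gives 3.16%, a gap beyond the usual scatter. These two structures differ in more than one place, so their values stand side by side without a computed step. Compound 3 `Cc1ccc(C(=O)c2sc(Nc3ccccc3)c(C(=O)O)c2C)cc1` awaits measurement in this assay and differs from compound 2 by methyl in place of methoxy on an aromatic carbon. Within the data shown here, no single-change step has been measured, so the expectation rests on the change itself: a small downward step from compound 2 to compound 3 of a number 7.7 percentage points lower from compound 2 to compound 3 (within the scatter) is expected. Compound 3 is estimated at 17%, with a range from 5% to 30%.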

Compound 3, a percentage reported as activity, at one concentration (the size of the read-out at that concentration, not a potency): 0.85%
Beside the measured number, compound 3's estimate is 16.2 percentage points above it, and the stated range ends above it.
By their numbers in this assay, from the lowest: compounds 3 and 1 (each within the scatter of the next); then compound 2.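

In this assay the change from 4-methoxyphenyl to 4-methylphenyl, para to a large group, gives a number 23.9 percentage points lower from compound 2 to compound 3 (beyond the scatter) and thus shows that this one position can carry a step beyond the scatter. With 4-methylphenyl in place, hydrogen in place of methyl on an oxygen next to a carbonyl group gives a number 2.3 percentage points lower from compound 1 to compound 3 (within the scatter) and so stays within the scatter. Nothing measured here explains either result. The compounds shown leave open whether an ethoxy or a hydroxyl group at this position would keep the read-out of compound 2.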